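A few compounds are considered here, and "the series" means these few. Any claim that something is new, unique, unknown or untested is made for them only; others in the source may bear on it.

The measured compounds:

Compound 1, `CNc1nc(C)c(-c2nc3ccccc3s2)c(N[C@@H]2C[C@H](CO)[C@@H](O)[C@H]2O)n1`, in an ADME assay on the whole organism (plasma) for pharmacokinetics, with Rattus norvegicus as the target, with a stated time of 6 h, at a dose of 10 mg/kg by the oral route (a higher number here means more compound in the circulation at the dose given, a lower number less compound in the circulation), gives 1080 ng.h/mL.
Compound 2, `Cc1nc(NCCC(F)(F)F)nc(N[C@@H]2C[C@H](CO)[C@@H](O)[C@H]2O)c1-c1nc2ccccc2s1`, in this assay gives 2560 ng.h/mL.

Within the data shown here, compound 2 stands highest of the two numbers; its only neighbour is compound 1, and the single measured step, a 2.4-fold higher number from compound 1 to compound 2 (0.37 log units; beyond the scatter), is the one that separates them. That step concerns 2,2,2-trifluoroethyl in place of hydrogen on a saturated chain carbon bound to a nitrogen on an aromatic ring.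

Compound 3 is `Cc1nc(NCc2ccncc2)nc(N[C@@H]2C[C@H](CO)[C@@H](O)[C@H]2O)c1-c1nc2ccccc2s1`. It differs from compound 2 in one place: pyridin-4-yl in place of 2,2,2-trifluoroethyl on a saturated chain carbon bound to a nitrogen on an aromatic ring. The chain keeps the same attachment point and length; only the group at its end changes.

Among the measured compounds shown here, no measured step describes an exchange of this kind, so the step from compound 1 to compound 2 says only that the group at the end of this chain can move the number beyond the scatter in this assay. With nothing else to lean on, a modest fall is expected for compound 3, a 2.1-fold lower number from compound 2 to compound 3 (0.33 log units; beyond the scatter), with a wide range either side.

For compound 3 the expected value in this assay is 1200 ng.h/mL, between 300 ng.h/mL and 4500 ng.h/mL.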

Compound 3, area under the concentration-time curve: 47.9 ng.h/mL
Estimate against measurement, compound 3: 25-fold (1.40 log units) above; the measured number lies below the stated range.
By their numbers in this assay, from the lowest: compound 3; then compound 1; then compound 2.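

In this assay, the group at the end of this chain proves able to move the number much further than the earlier pair could show: pyridin-4-yl in place of 2,2,2-trifluoroethyl gives a 53-fold lower number from compound 2 to compound 3 (1.73 log units; beyond the scatter) and leaves the earlier step looking small. Adding to the chain of compound 1 does not raise the number as such, since the direction depends on the group that enters: 2,2,2-trifluoroethyl raised it, whereas pyridin-4-yl in place of hydrogen gives a 23-fold lower number from compound 1 to compound 3 (1.35 log units; beyond the scatter) and takes the number well under that of the smaller compound. Nothing at hand explains why this ring has so large an effect on the chain. The compounds shown leave open whether the fall goes with the ring nitrogen or with any aromatic ring on this chain, a question that a phenyl or a pyridin-3-yl group in the same place would begin to answer. They also leave open whether a saturated ring such as cyclopropyl, or a longer chain ending in a hydroxyl, would stay nearer compound 2 or fall towards compound 3.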